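Cytotoxicity on liver cells: trading a trifluoromethylphenyl for fluorophenyl

The compounds below may be only part of what the source reports. "The series", "measured", "known", "first", "only" and "open" are said of these compounds alone.

The account begins with two measured compounds. Compound 1, `O=C(N/N=C/Nc1ccc(C(=O)O)c(O)c1)c1cccc(F)c1`, was tested in an ADME assay on HepG2 cells (Homo sapiens) for cytotoxicity, read by MTT assay (a higher number here means a weaker inhibitor, a lower number a stronger inhibitor), and compound 1 gives 934000 nM. Compound 2, `O=C(N/N=C/N1CCN(c2cc3c(cc2F)c(=O)c(C(=O)O)cn3C2CC2)CC1)c1ccc(C(F)(F)F)cc1`, shares the hydrazide-type linkage but carries a different core, and in this assay compound 2 gives 347000 nM. Among the measured compounds shown here, compound 2 therefore stands at the lower of the two numbers, with compound 1 as its only neighbour and that gap beyond the scatter. Both compounds sit at concentrations that mark them as weak inhibitors in this readout.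

The step now followed leads to compound 3, `O=C(N/N=C/N1CCN(c2cc3c(cc2F)c(=O)c(C(=O)O)cn3C2CC2)CC1)c1cccc(F)c1`, which differs from compound 2 in one place: 3-fluorophenyl in place of 4-(trifluoromethyl)phenyl on a carbonyl carbon, on a carbonyl carbon whose other neighbour is an amide-type nitrogen. For the measured compounds named here, no measured pair isolates this exchange, so its size is unknown; the only hint is that compound 1, which also carries the 3-fluorophenyl, returns the higher number, though its core differs as well. Compound 3 is expected to show a small move upward, within or barely beyond the scatter, as a 1.4-fold higher number from compound 2 to compound 3 (0.14 log units; within the scatter). Compound 3 is thus estimated at 480000 nM, in a range from 220000 nM to 1000000 nM.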

Compound 3, half-maximal inhibitory concentration: > 812000 nM
Compound 3: no number, only a limit; the forecaster's own chance of this, stated with the estimate: 20%; at least 1.6-fold (0.22 log units) between middle value and limit.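

In this assay, compound 3 carries a limit of the assay and not a number: > 812000 nM. Even so, with the shared core held constant, 3-fluorophenyl in place of 4-(trifluoromethyl)phenyl on a carbonyl carbon gives an at least 2.3-fold higher number from compound 2 to compound 3 (0.36 log units; beyond the scatter), so the group at this place does affect the reading, something that compound 1 and compound 2 could not show, as they differ in more than one place. The step has a lower bound only, so its full size remains unknown, and the reading rests on a value that sits at the assay limit: the limit of > 812000 nM in this assay, at which 1 of the 3 values shown sits.

Compound 2 and compound 3 differ in both the kind of substituent and where it sits on the ring, so they do not tell which of these accounts for the step, and a plain phenyl or a pyridyl ring on the same carbonyl carbon would help to separate the two. On these data alone, it also remains open whether an exchange of this kind would give a step in the same direction on the core of compound 1.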